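Cyclopropyl for Methyl on an Amide Nitrogen

The compounds below may be only part of what the source reports. "The series", "measured", "known", "first", "only" and "open" are said of these compounds alone.

Measured so far:
Compound 1 `O=C(COc1nnnn1-c1cccc2ccccc12)Nc1ccccc1[N+](=O)[O-]`: 0.05 h
Compound 2 `CN(C(=O)CCC(=O)Nc1ccc(-c2ccc(OCC(=O)O)cc2)cc1Cl)c1ccc(C(C)(C)C)cc1Cl`: 0.9 h

In an in vitro ADME assay on microsomes from liver (Homo sapiens) for metabolic stability (on this read-out higher numbers stand for a longer-lived compound and lower numbers for a shorter-lived compound), compound 2 stands highest of the two numbers, and compound 1 lies far lower, a gap beyond the usual scatter. Compound 3 `CC(C)(C)c1ccc(N(C(=O)CCC(=O)Nc2ccc(-c3ccc(OCC(=O)O)cc3)cc2Cl)C2CC2)c(Cl)c1` differs from compound 2 in one place: cyclopropyl in place of methyl on an amide-type nitrogen. Among the measured compounds shown here, no measured pair shows this change, so its effect in this assay is not known from these data. A small step upward, close to the scatter, is expected, a 1.4-fold higher number from compound 2 to compound 3 (0.16 log units; within the scatter). For compound 3 the expected half-life is 1.3 h, in a range from 0.5 h to 3.5 h.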

Compound 3, half-life: 0.25 h
Beside the measured number, compound 3's estimate is 5.2-fold (0.72 log units) above it; the measured number lies below the stated range.
By their numbers in this assay, from the lowest: compound 1; then compound 3; then compound 2.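

In this assay, putting cyclopropyl in place of methyl on the amide-type nitrogen gives a 3.6-fold lower number from compound 2 to compound 3 (0.56 log units; beyond the scatter), so the compound becomes shorter-lived. This shows that the group on this nitrogen matters for this read-out, even though the change is small and adds no hydrogen-bond donors or acceptors. Nothing available explains why the number falls.

As far as these compounds go, whether ethyl, isopropyl or a plain hydrogen on this nitrogen would sit closer to methyl or to cyclopropyl remains open. So does whether the same swap would act alike on another core.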